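Inverting the Ring Stereocentre of a Weak Cellular Inhibitor

The compounds below may be only part of what the source reports. "The series", "measured", "known", "first", "only" and "open" are said of these compounds alone.

Compound 1 `CCOC(=O)[C@H]1CCN(S(=O)(=O)c2ccc(S(=O)(=O)N(CC)CC)cc2)C1` stands at the highest number of the two measured in a functional assay on BXPC-3 cells (Homo sapiens) for inhibition, read by MTT assay, with a stated time of 7 days (a lower number here means a stronger inhibitor, a higher number a weaker inhibitor), giving 29300 nM; compound 2 `CCN(CC)C(=O)[C@@H]1CCCN(S(=O)(=O)c2ccc(S(=O)(=O)N(CC)CC)cc2)C1` gives 10500 nM, a gap that lies beyond the scatter. Compound 3 `CCOC(=O)[C@@H]1CCN(S(=O)(=O)c2ccc(S(=O)(=O)N(CC)CC)cc2)C1` is the mirror partner of compound 1: the two compounds have the same atoms and bonds and differ only in configuration as drawn: 1 of 1 stereo elements differ; a stereocentre at a saturated ring carbon is drawn S in compound 1 and R in compound 3. Among the measured compounds shown here, no measured pair shows a change of this kind, so the data give no guide to its size or direction; a change in configuration alone may leave the number within the scatter or shift it either way. The step of a 1.0-fold higher number from compound 1 to compound 3 (0.01 log units; within the scatter) is expected to be small. Compound 3 is estimated at 30000 nM, within a range from 8000 nM to 100000 nM.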

Compound 3, half-maximal inhibitory concentration: 10000 nM
Estimate against measurement, compound 3: 3.0-fold (0.48 log units) above, and the stated range covers the measured number.
By their numbers in this assay, from the lowest: compounds 3 and 2 (each within the scatter of the next); then compound 1.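

In this assay the change from S to R at the saturated ring carbon gives a 2.9-fold lower number from compound 1 to compound 3 (0.47 log units; beyond the scatter), the first measured sign that configuration alone moves the number at this position, with the R form the stronger of this mirror pair. The step can be laid on that stereocentre alone because nothing else separates the pair: the fact that compounds 1 and 3 differ only in the configuration as drawn. The compounds shown leave open whether the same preference for R would hold with a carboxylic acid or a primary amide in place of the ethyl ester at this carbon.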